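A few compounds are considered here, and "the series" means these few. Any claim that something is new, unique, unknown or untested is made for them only; others in the source may bear on it.

Within the data shown here, in an ADME assay on CEM-SS cells (Homo sapiens) for cytotoxicity, read by XTT assay (on this read-out higher numbers stand for lower toxicity in this test and lower numbers for higher toxicity in this test), compound 1 (`CN(O)C(=O)c1cc2ccn(Cc3ccc(F)cc3)c2cn1`) gives 135000 nM as the only true number. Compound 2 (`CN(O)C(=O)c1cc2c(CN3CCC(O)C3)cn(Cc3ccc(F)cc3)c2cn1`) stands at > 100000 nM in the same test, and this is a limit and not a number. Compound 3 (`CN(O)C(=O)c1cc2c(COC3CCOCC3)cn(Cc3ccc(F)cc3)c2cn1`) gives > 100000 nM here, which is again a limit. The picture is therefore the limit of > 100000 nM in this assay, at which 2 of the 3 values shown sit, and compound 2 is one of those two.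

Compound 4 (`CN(O)C(=O)c1cc2c(C(=O)N3CCC[C@@H]3CO)cn(Cc3ccc(F)cc3)c2cn1`) departs from compound 2 at one place, on an aromatic carbon of a five-membered aromatic ring with 1 nitrogen: (2-(hydroxymethyl)pyrrolidin-1-yl)carbonyl in place of (3-hydroxypyrrolidin-1-yl)methyl on an aromatic carbon (the amide-linked (2-(hydroxymethyl)pyrrolidin-1-yl)carbonyl takes the place of (3-hydroxypyrrolidin-1-yl)methyl).

The measured steps that bear on this are a step that the limit leaves unreadable from compound 1 to compound 2 and a step that the limit leaves unreadable from compound 1 to compound 3 and a step that the two limits leave unreadable from compound 2 to compound 3 so none of them offers a size. Among the measured compounds shown here, with compound 1 at 135000 nM as the one true number, the expectation in this assay is no change beyond the scatter. The expected step is a step that the limit leaves unreadable from compound 2 to compound 4 with no firm direction. Compound 4 is estimated at 110000 nM with an expected range from 50000 nM to 220000 nM on this read-out.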

Compound 4, half-maximal cytotoxic concentration: > 32000 nM
Compound 4 gave a limit, no number; the forecaster's own chance of this, stated with the estimate: 60%; the middle value does not contradict the limit.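

Among these compounds, compound 4 gives > 32000 nM as a limit and not a number, so no step linking it to compound 1, compound 2 or compound 3 can be read. In this assay the compounds shown leave open whether compound 4 differs at all from these three.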